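Bromo substitution across two cores in the cytotoxicity read-out

The compounds below may be only part of what the source reports. "The series", "measured", "known", "first", "only" and "open" are said of these compounds alone.

Measured compounds:
Compound 1 `CCCNC(=O)C1CCN(C(=O)c2cc3ccsc3n2Cc2ccc(OC)cc2)CC1`: 23400 nM
Compound 2 `CCCNC(=O)C1CCN(C(=O)c2cccn2Cc2ccc(OC)cc2)CC1`: only a limit, > 100000 nM
Compound 3 `CCCNC(=O)C1CCN(C(=O)c2cc3cc(Br)sc3n2Cc2ccc(OC)cc2)CC1`: only a limit, > 100000 nM

In an ADME assay on HEK-293T cells (Homo sapiens) for cytotoxicity, read by luminescence and CellTiter-Glo, with a stated time of 24 h (on this read-out lower numbers stand for higher toxicity in this test and higher numbers for lower toxicity in this test), compound 1 gives 23400 nM. Compound 3 reaches only a limit of this assay, > 100000 nM. Compound 2 likewise reaches only a limit, > 100000 nM. The difference between the core of compound 1 and the core of compound 2 is not broken down here.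

The measured step is an at least 4.2-fold higher number from compound 1 to compound 3 (0.63 log units; beyond the scatter), the change being (bromo in place of hydrogen on an aromatic carbon). Its size is bounded by the limit of > 100000 nM in this assay, at which 2 of the 3 values shown sit, so the true step may be larger than shown.

The unmeasured compound 4 `CCCNC(=O)C1CCN(C(=O)c2ccc(Br)n2Cc2ccc(OC)cc2)CC1` carries the same kind of change relative to compound 2: bromo in place of hydrogen on an aromatic carbon. The place is not the same: here the bromo sits on a five-membered aromatic ring with 1 nitrogen, next to the ring nitrogen and next to the ring atom that bears a 4-methoxybenzyl group, whereas in compound 3 it sits on a five-membered aromatic ring with 1 sulfur, part of a fused system, next to the ring sulfur.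

Compound 2 already sits at the limit, so the expected step that the limit leaves unreadable from compound 2 to compound 4 is estimated to be small, resting on the direction of an at least 4.2-fold higher number from compound 1 to compound 3 (0.63 log units; beyond the scatter). Compound 4 is expected to give about 150000 nM in this assay, most likely again as a limit rather than a number, with a range of 60000 nM to 400000 nM.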

Compound 4, half-maximal cytotoxic concentration: > 100000 nM
Compound 4: no number, only a limit (the forecaster's own chance of this, stated with the estimate: 80%); the middle value does not contradict the limit.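

Compound 2 and compound 4 both stand only as limits in this assay, so no step can be read between them: the limit of > 100000 nM in this assay, at which 3 of the 4 values shown sit.

The compounds shown leave open whether bromo in place of hydrogen on an aromatic carbon changes the read-out at all on the core of compound 2, and so whether the step seen on the core of compound 1 carries over to it.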